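The source may hold more compounds than are shown below. What is called first, only, known or untested is meant among the compounds shown, and "the series" means these compounds.

Measured so far in a functional assay on KB cells (Homo sapiens) for cytotoxicity; on this read-out lower numbers stand for an effect already at smaller amounts and higher numbers for an effect only at larger amounts of compound:
Compound 1 `COC1=C(C)C(=O)/C(=C(O)/C=C/c2ccc(OC)cc2)C(=O)C1(C)C` gives 2.9 ug/mL
Compound 2 `COC1=C(C)C(=O)/C(=C(O)/C=C/c2cccc(OC)c2)C(=O)C1(C)C` gives 2.4 ug/mL

Within the data shown here, compound 2 stands level with the only other number at hand. The step between them (a 1.2-fold lower number from compound 1 to compound 2 (0.08 log units; within the scatter)) lies within the scatter. Compound 3 `COC1=C(C)C(=O)/C(=C(O)/C=C/c2ccccc2OC)C(=O)C1(C)C` differs from compound 2 in one place (2-methoxyphenyl in place of 3-methoxyphenyl on a double-bonded chain carbon bound to a double-bonded chain carbon) with 2-methoxyphenyl in place of 3-methoxyphenyl on a double-bonded chain carbon bound to a double-bonded chain carbon. Among the measured compounds shown here, the one measured step bearing on this is the change from 4-methoxyphenyl to 3-methoxyphenyl at that same place, and it was small (a 1.2-fold lower number from compound 1 to compound 2 (0.08 log units; within the scatter)). For the measured compounds named here, the 2-methoxyphenyl group itself has no measurement yet, so this support is thin. No step beyond the scatter is therefore expected in this assay in either direction. The expected step is a 1.0-fold higher number from compound 2 to compound 3 (0.02 log units; within the scatter) and would stay within the scatter. Compound 3 is estimated at 2.5 ug/mL with an expected range from 1.2 ug/mL to 5 ug/mL in this read-out.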

Compound 3, concentration for half-maximal effect: 2.8 ug/mL
The estimate for compound 3 lay 1.1-fold (0.05 log units) below the measured number, within the range that was stated.
By their numbers in this assay, from the lowest: compounds 2, 3 and 1 (each within the scatter of the next).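

With this third methoxyphenyl group at the place on a double-bonded chain carbon bound to a double-bonded chain carbon, all three arrangements of the methoxy group on the phenyl ring can now be compared in this assay. Neither 2-methoxyphenyl in place of 3-methoxyphenyl (a 1.2-fold higher number from compound 2 to compound 3 (0.07 log units; within the scatter)) nor 2-methoxyphenyl in place of 4-methoxyphenyl (a 1.0-fold lower number from compound 1 to compound 3 (0.02 log units; within the scatter)) moves the number beyond the scatter, so among compounds 1, 2 and 3 the read-out does not separate these groups. Nothing measured on these compounds offers an explanation for this result.

The compounds shown leave open whether a different substituent on that phenyl ring, such as an amine, a carboxylic acid or a longer ethoxy or butoxy chain, would shift the number beyond the scatter. They also leave open how an unsubstituted phenyl group would compare at this place.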